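The source may report more compounds than this note shows. Statements on the series, on what has been measured and on what is new or still open speak of the compounds shown alone.

Of the compounds shown here, three sharing one core have been measured in an assay on CHO cells for displacement of a labelled ligand from adenosine receptor A1 (Homo sapiens), read by scintillation counting, with a stated time of 90 min; a lower number here means a stronger inhibitor, a higher number a weaker inhibitor. Compound 1 `N#Cc1c(N)nc(SCc2cccc(C(N)=O)c2)c(C#N)c1-c1ccc(OCC2CC2)cc1` gives 83 nM in this assay. Compound 2 `N#Cc1c(N)nc(SCc2ccn[nH]2)c(C#N)c1-c1ccc(OCC2CC2)cc1` gives 552 nM, and compound 3 `N#Cc1c(N)nc(SCc2csc(N)n2)c(C#N)c1-c1ccc(OCC2CC2)cc1` gives 140 nM. Within these three, compound 3 stands second highest: its number sits close to that of compound 1, the two being within the scatter, while compound 2 lies further off. The measured steps show how much the group on the saturated chain carbon bound to a sulfur matters: a 6.7-fold higher number from compound 1 to compound 2 (0.82 log units; beyond the scatter), a 3.9-fold lower number from compound 2 to compound 3 (0.60 log units; beyond the scatter), and a 1.7-fold higher number from compound 1 to compound 3 (0.23 log units; within the scatter).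

Compound 4 `N#Cc1c(N)nc(SCC(=O)NO)c(C#N)c1-c1ccc(OCC2CC2)cc1` is not yet measured. hydroxycarbamoyl in place of 2-amino-1,3-thiazol-4-yl on a saturated chain carbon bound to a sulfur The steps at this same place all bear on it, and they were modest. Among the measured compounds shown here, the hydroxycarbamoyl group is smaller than every group tried so far, so the new step has no close precedent. A modest weakening of the number is expected, roughly a 2.5-fold higher number from compound 3 to compound 4 (0.40 log units; beyond the scatter), with real uncertainty in direction. Compound 4 is therefore estimated at 350 nM, within a range of 90 nM to 1400 nM.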

Compound 4, inhibition constant: 536 nM
For compound 4 the middle estimate is 1.5-fold (0.19 log units) below the measured one; measured number inside the range.
By their numbers in this assay, from the lowest: compounds 1 and 3 (each within the scatter of the next); then compounds 4 and 2 (each within the scatter of the next).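

Among the compounds shown here, the hydroxycarbamoyl group is the first group at this place without a ring, yet in this assay it stands level with the 1H-pyrazol-5-yl group, with a 1.0-fold lower number from compound 2 to compound 4 (0.01 log units; within the scatter). It gives a weaker result than the 2-amino-1,3-thiazol-4-yl and 3-carbamoylphenyl groups, with a 3.8-fold higher number from compound 3 to compound 4 (0.58 log units; beyond the scatter) and a 6.5-fold higher number from compound 1 to compound 4 (0.81 log units; beyond the scatter), but a ring alone does not decide the number, as compound 2 carries one and still sits with compound 4. Nothing available explains these steps.

With only one ringless group shown, it remains open how such groups behave in general on the saturated chain carbon bound to a sulfur. On these data alone, whether a plain carbamoyl group or a carboxylic acid there would sit nearer compound 3 or compound 4 also remains open.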